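This account rests on a few compounds, and the source may have more. Where it says the series, first, only, none or still open, it means among the compounds named here.

In a functional assay on DU-145 cells (Homo sapiens) for cytotoxicity, read by CCK-8 assay (on this read-out lower numbers stand for stronger inhibition and higher numbers for weaker inhibition), two compounds sharing one core have been measured so far. Compound 1 `Oc1ccc(-c2cc(-c3ccsc3)cc(-c3ccccc3O)n2)cc1`, which carries a 2-hydroxyphenyl group, reads > 50000 nM, and this is a limit of the assay and not a number. For the measured compounds named here, compound 2 `Oc1ccc(-c2cc(-c3ccsc3)cc(-c3ccc(O)cc3)n2)cc1`, with 4-hydroxyphenyl in that place, gives 2060 nM, the only true number so far. That exchange produced a large change: an at least 24-fold lower number from compound 1 to compound 2 (1.38 log units; beyond the scatter).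

Compound 3 `Oc1ccc(-c2cc(-c3ccoc3)cc(-c3ccc(O)cc3)n2)cc1` has not yet been measured. It differs from compound 2 in one place, opposite the ring nitrogen, where furan-3-yl stands in place of thiophen-3-yl: furan-3-yl in place of thiophen-3-yl on an aromatic carbon. Going by the values given here, the one measured step concerns the hydroxyphenyl groups, so it says nothing direct about this five-membered ring, and its size should not be carried over. Among the compounds with values here, no measured step touches this position. With a single ring hetero atom exchanged and the two 4-hydroxyphenyl groups kept, compound 3 is expected to stay close to compound 2, which gives 2060 nM in this assay. The expected change is small, within the scatter, with a slight lean towards a higher number: a 1.2-fold higher number from compound 2 to compound 3 (0.08 log units; within the scatter). The estimate for compound 3 is 2500 nM, with an expected range from 900 nM to 8000 nM.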

Compound 3, half-maximal inhibitory concentration: 3440 nM
Beside the measured number, compound 3's estimate is 1.4-fold (0.14 log units) below it; low and high end bracket the measured number.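

In this assay, for the compounds shown here, this is the first measured change at the position opposite the ring nitrogen, and furan-3-yl in place of thiophen-3-yl gives a 1.7-fold higher number from compound 2 to compound 3 (0.22 log units; within the scatter). The two compounds therefore cannot be told apart in this assay: with the two 4-hydroxyphenyl groups kept, this five-membered aromatic ring can carry either sulfur or oxygen as its hetero atom without a step beyond the scatter, whereas the earlier step on a hydroxyphenyl group, an at least 24-fold lower number from compound 1 to compound 2 (1.38 log units; beyond the scatter), lies beyond it. Nothing shown gives a reason for the size of this new step.

The compounds shown leave open whether this position accepts more than these two closely matched rings, for instance a plain phenyl ring, a morpholine, an amine or a carboxylic acid, or a longer chain in place of the ring. They also leave open whether the exchange of thiophen-3-yl for furan-3-yl would read the same with a 2-hydroxyphenyl group on the core, as in compound 1, and how far any such result would hold in other cell lines.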